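Aryl sulfonate ureas: cyclising the pentyl chain

The compounds below may be only part of what the source reports. "The series", "measured", "known", "first", "only" and "open" are said of these compounds alone.

Compound 1 `CC(=O)Nc1ccc(S(=O)(=O)Oc2ccccc2C(C)C)cc1` and compound 2 `CCCCCNC(=O)Nc1ccc(S(=O)(=O)Oc2ccccc2C(C)C)cc1` share one core and differ only at the carbonyl. Among the compounds with values here, in a functional assay on MCF7 cells (Homo sapiens) for antiproliferative activity, read by sulforhodamine B assay, with a stated time of 48 h (a higher number here means a weaker inhibitor, a lower number a stronger inhibitor), compound 1 gives 16000 nM, while compound 2 gives 4000 nM; the step of a 4.0-fold lower number from compound 1 to compound 2 (0.60 log units; beyond the scatter) is the only measured step so far, and compound 2 therefore holds the lowest of the two numbers, with compound 1 as its only neighbour.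

Compound 3 `CC(C)c1ccccc1OS(=O)(=O)c1ccc(NC(=O)NCC2CCCC2)cc1` keeps the urea and changes the chain: cyclopentyl in place of butyl on a saturated chain carbon bound to an amide-type nitrogen. Within the data shown here, no measured step touches this part of the molecule; the one step known, from compound 1 to compound 2, changes the carbonyl substituent altogether and does not bear on a chain-to-ring swap of equal donor and acceptor count. With nothing to indicate a direction, the step of a 1.1-fold lower number from compound 2 to compound 3 (0.06 log units; within the scatter) is expected to stay within the scatter. Compound 3 is therefore estimated at 3500 nM in this assay, between 1500 nM and 8000 nM.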

Compound 3, half-maximal inhibitory concentration: 7100 nM
Compound 3: the middle estimate sits 2.0-fold (0.31 log units) below what was measured, within the range that was stated.
By their numbers in this assay, from the lowest: compounds 2 and 3 (each within the scatter of the next); then compound 1.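

In this assay, cyclopentyl in place of butyl on a saturated chain carbon bound to an amide-type nitrogen gives a 1.8-fold higher number from compound 2 to compound 3 (0.25 log units; within the scatter) within the scatter, so at this position the data do not separate the ring of carbon only from the open chain. Set against the methyl on the carbonyl, (cyclopentylmethyl)amino gives a 2.3-fold lower number from compound 1 to compound 3 (0.35 log units; beyond the scatter) and stays beyond the scatter, so the advantage over compound 1 is not confined to the pentylamino group of compound 2. No evidence is available to explain how the ring and the chain compare here.

Going by these compounds, it remains open whether a longer chain, or an amine or a carboxylic acid on the chain, would move the number beyond the scatter. A phenyl ring in the place of cyclopentyl also remains an open case.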